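A trifluoromethyl group added to compound 2

The source may report more compounds than this note shows. Statements on the series, on what has been measured and on what is new or still open speak of the compounds shown alone.

In a functional assay on MCF7 cells (Homo sapiens) for cytotoxicity, read by MTT assay, with a stated time of 24 h (a lower number here means a stronger inhibitor, a higher number a weaker inhibitor), compound 1 (`O=c1nc2ccccn2cc1Cc1ccc(F)cc1C(F)(F)F`) gives 9870 nM and compound 2 (`O=c1nc2ccc(Cl)cn2cc1Cc1ccc(F)cc1`) gives 10400 nM, so these two stand within the scatter of each other. Compound 3 (`O=c1nc2ccc(Cl)cn2cc1Cc1ccc(F)cc1C(F)(F)F`) is compound 2 with trifluoromethyl in place of hydrogen on an aromatic carbon. For the measured compounds named here, no measured pair isolates this change, so the expectation rests on compound 1, which bears trifluoromethyl and gives 9870 nM. Only a small move towards a lower number, within the scatter, is expected in this assay. The expected step is a 1.4-fold lower number from compound 2 to compound 3 (0.14 log units; within the scatter). For compound 3 the estimate is 7500 nM, with an expected range from 3000 nM to 18000 nM.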

Compound 3, half-maximal inhibitory concentration: 181000 nM
Estimate against measurement, compound 3: 24-fold (1.38 log units) below; measured number above the stated range.
By their numbers in this assay, from the lowest: compounds 1 and 2 (each within the scatter of the next); then compound 3.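

In this assay, trifluoromethyl on this aromatic carbon, ortho to a large group, gives a sharp loss with chloro present (in a 17-fold higher number from compound 2 to compound 3 (1.24 log units; beyond the scatter)), and chloro gives a loss of like size with trifluoromethyl present (in an 18-fold higher number from compound 1 to compound 3 (1.26 log units; beyond the scatter)). The large penalty thus appears with both groups on the core, which compound 1 and compound 2, each carrying only one, did not show. No evidence here bears on the reason for it. The compounds shown leave open whether methyl or an amine on the same carbon would fare the same with chloro present. They also leave open how the parent lacking both chloro and trifluoromethyl stands.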